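Varying the group on the sulfonyl sulfur

The compounds below may be only part of what the source reports. "The series", "measured", "known", "first", "only" and "open" are said of these compounds alone.

Three compounds have been measured in an assay on isolated protein for inhibition of malate dehydrogenase, mitochondrial (Sus scrofa), with stated times of 45 min and 30 min; on this read-out higher numbers stand for weaker inhibition and lower numbers for stronger inhibition:
Compound 1 `O=S(=O)(Nc1ccc(-c2nc3ccccc3o2)cc1)c1ccc(Cl)s1` gives > 63000 nM.
Compound 2 `COc1ccccc1S(=O)(=O)Nc1ccc(-c2nc3ccccc3o2)cc1` gives > 63000 nM.
Compound 3 `O=S(=O)(Nc1ccc(-c2nc3ccccc3o2)cc1)c1ccc(Cl)c(Cl)c1` gives > 63000 nM.

Each of these three values is a limit of the assay, not a number. Compound 3 therefore stands at the limit, as the limit of > 63000 nM in this assay, at which 3 of the 3 values shown sit, states for all three. The steps between them cannot be sized: a step that the two limits leave unreadable from compound 1 to compound 2, a step that the two limits leave unreadable from compound 1 to compound 3 and a step that the two limits leave unreadable from compound 2 to compound 3 are all unreadable.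

Compound 4 `Cc1cccc(S(=O)(=O)Nc2ccc(-c3nc4ccccc4o3)cc2)c1` is not yet measured. It differs from compound 3 in one place: 3-methylphenyl in place of 3,4-dichlorophenyl on a sulfonyl sulfur. Of the measured steps, only the change of the group on the sulfonyl sulfur bears on it, and none of those changes gave a readable size, since every compound sits at the limit. No step beyond the scatter can be predicted from them in this assay. Compound 4 is accordingly expected to give about 100000 nM, with a range from 40000 nM to 300000 nM. The expected step is a step that the limit leaves unreadable from compound 3 to compound 4.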

Compound 4, half-maximal inhibitory concentration: > 63000 nM
Compound 4 gave a limit, no number (the forecaster's own chance of this, stated with the estimate: 85%); the middle value lies beyond the limit too.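

In this assay compound 4 gives > 63000 nM as a limit of the assay, not a number. No step between compound 4 and compounds 1, 2 and 3 can be read, since all four stop at the same point: the limit of > 63000 nM in this assay, at which 4 of the 4 values shown sit.

The four compounds leave open how their groups on the sulfonyl sulfur rank, and whether any such group on this core gives a measurable inhibition.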